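A Hydroxy Group in Place of an Azide

A few compounds are considered here, and "the series" means these few. Any claim that something is new, unique, unknown or untested is made for them only; others in the source may bear on it.

Compound 1 `[N-]=[N+]=N[C@@H]1C(n2ccc(=O)[nH]c2=O)[Se][C@H](CO)[C@H]1O`: in a functional assay on K562 cells (Homo sapiens) for cytotoxicity, read by sulforhodamine B assay (on this read-out lower numbers stand for stronger inhibition and higher numbers for weaker inhibition), compound 1 gives > 100000 nM, which is a limit of the assay.
Compound 2 `Cc1cn(C2[Se][C@H](CO)[C@@H](O)[C@@H]2N=[N+]=[N-])c(=O)[nH]c1=O`: in this assay compound 2 gives > 100000 nM, again a limit.
Compound 3 `[N-]=[N+]=N[C@@H]1C(n2cc(Br)c(=O)[nH]c2=O)[Se][C@H](CO)[C@H]1O`: in this assay compound 3 gives > 100000 nM, again a limit.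

Compound 1 therefore stands only at a limit in this assay; no number is known for it. The three measured compounds share one core and differ only in the group on an aromatic carbon. The steps a step that the two limits leave unreadable from compound 1 to compound 2, a step that the two limits leave unreadable from compound 1 to compound 3 and a step that the two limits leave unreadable from compound 2 to compound 3 cannot be sized, because all three values sit at the limit of > 100000 nM in this assay, at which 3 of the 3 values shown sit.

Compound 4 `O=c1ccn(C2[Se][C@H](CO)[C@@H](O)[C@@H]2O)c(=O)[nH]1` differs from compound 1 in another place: hydroxy in place of azido on a saturated ring carbon. Among the compounds with values here, none of the measured steps touches this saturated ring carbon, so none of them bears directly on the change, and even the steps on the aromatic carbon are unreadable. There is thus no measured basis for expecting the change to push the value in either direction beyond the scatter.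

With every measured compound at the limit, the expected step of a number no higher from compound 1 to compound 4 (the limit leaves the size open) from compound 1 to compound 4 is most plausibly one that stays at that limit. Compound 4 is estimated at 100000 nM, with a range from 40000 nM to 300000 nM, and most likely the assay will again report only a limit.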

Compound 4, half-maximal inhibitory concentration: > 100000 nM
Compound 4 gave a limit, no number (the forecaster's own chance of this, stated with the estimate: 80%); the middle value sits exactly at the limit.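

Compound 4 also stands only at a limit, so no new step can be read between compound 1 and compound 4, and the exchange of azido for hydroxy cannot be sized: the limit of > 100000 nM in this assay, at which 4 of the 4 values shown sit.

The compounds shown leave open what real value any of them has in this assay, and whether azido or hydroxy makes any difference there.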